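This account rests on a few compounds, and the source may have more. Where it says the series, first, only, none or still open, it means among the compounds named here.

Within the data shown here, compound 2 `CC(=O)c1cccc(N/C(=N/[C@@H]2c3cc(C#N)ccc3OC(C)(C)[C@H]2O)NC#N)c1` gives 8400 nM in a functional assay (aorta) with Rattus norvegicus as the target (a higher number here means a weaker inhibitor, a lower number a stronger inhibitor), the only number available in this set. Compound 1 `CC1(C)Oc2ccc(C#N)cc2[C@@H](/N=C(\NC#N)Oc2ccccc2)[C@@H]1O` yields only a limit in this assay, > 100000 nM, as recorded in the limit of > 100000 nM in this assay, at which 1 of the 2 values shown sits. Among the measured compounds shown here, the single measured step, an at least 11-fold lower number from compound 1 to compound 2 (1.07 log units; beyond the scatter), exchanged phenoxy for (3-acetylphenyl)amino on the carbon with a double bond to nitrogen and says nothing about substituents on the aryl ring. Compound 3 `Cc1ccc(N/C(=N/[C@@H]2c3cc(C#N)ccc3OC(C)(C)[C@H]2O)NC#N)cc1` differs from compound 2 by 4-methylphenyl in place of 3-acetylphenyl on an amine nitrogen. For the measured compounds named here, no measured step bears on this change, so a step of a 1.2-fold higher number from compound 2 to compound 3 (0.08 log units; within the scatter) is expected, within the scatter. The estimate for compound 3 in this assay is 10000 nM, between 3000 nM and 40000 nM.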

Compound 3, half-maximal inhibitory concentration: 2700 nM
Compound 3: the middle estimate sits 3.7-fold (0.57 log units) above what was measured; the measured number lies below the stated range.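

In this assay, the aryl group on the amine nitrogen itself moves the number: a 3.1-fold lower number from compound 2 to compound 3 (0.49 log units; beyond the scatter), with 4-methylphenyl in place of 3-acetylphenyl. The step of an at least 37-fold lower number from compound 1 to compound 3 (1.56 log units; beyond the scatter) gives a second aryl amine that stands clear of phenoxy, though only as a bound, since the value for compound 1 is a limit: the limit of > 100000 nM in this assay, at which 1 of the 3 values shown sits.

This change swaps both the substituent and where it sits on the ring, and the compounds shown cannot separate the two. On these data alone, how a plain phenyl, 3-methylphenyl or 4-acetylphenyl on the amine nitrogen would compare remains open.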